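The source may report more compounds than this note shows. Statements on the series, on what has been measured and on what is new or still open speak of the compounds shown alone.

Of the compounds shown here, three sharing one core have been tested in an assay on HeLa cells for inhibition of sphingosine-1-phosphate transporter SPNS2 (Mus musculus), read by LC-MS, tested at 2 uM; on this read-out higher numbers stand for more inhibition at the one concentration tested (going by the name of the read-out) and lower numbers for less inhibition. Compound 1 `CCCCCCCCCCc1ccc(-c2noc(CCCN)n2)cc1` gives 67%, compound 2 `CCCCCCCCCCc1ccc(-c2noc(CC3CCNC3)n2)cc1` gives 44%, and compound 3 `CCCCCCCCCCc1ccc(-c2noc([C@@H]3CCCN3)n2)cc1` gives 21%, the lowest of the three: the changes are a number 46 percentage points lower from compound 1 to compound 3 (beyond the scatter) and a number 23 percentage points lower from compound 2 to compound 3 (beyond the scatter). Compound 4 `CCCCCCCCCCc1ccc(-c2noc(CN3CCNCC3)n2)cc1` differs from compound 3 in one place: (piperazin-1-yl)methyl in place of pyrrolidin-2-yl on an aromatic carbon. Among the compounds with values here, both measured steps onto compound 3 run the same way: putting pyrrolidin-2-yl in place of 3-aminopropyl or of (pyrrolidin-3-yl)methyl lowered inhibition, so the move to (piperazin-1-yl)methyl, again a ring carried on a chain carbon, is expected to raise it, though no measured step holds a six-membered ring with two hetero atoms. The expected step is a number 14 percentage points higher from compound 3 to compound 4 (beyond the scatter). Compound 4 is therefore estimated at 35%, with a range from 10% to 60%.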

Compound 4, a percentage reported as inhibition, at one concentration (the size of the read-out at that concentration, not a potency): 19%
Compound 4: middle estimate off by 16 percentage points, on the high side; low and high end bracket the measured number.
By their numbers in this assay, from the lowest: compounds 4 and 3 (each within the scatter of the next); then compound 2; then compound 1.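

In this assay, swapping pyrrolidin-2-yl for (piperazin-1-yl)methyl leaves inhibition indistinguishable (a number 2 percentage points lower from compound 3 to compound 4 (within the scatter)), so a ring carried on a chain carbon does not by itself bring inhibition back at this position. With that chain carbon kept, the group on it clearly matters: piperazin-1-yl gives less inhibition than pyrrolidin-3-yl (a number 25 percentage points lower from compound 2 to compound 4 (beyond the scatter)) or 2-aminoethyl (a number 48 percentage points lower from compound 1 to compound 4 (beyond the scatter)). Nothing available explains these differences. As far as these compounds go, it remains open whether a longer chain such as 4-aminobutyl would go beyond compound 1, and how a piperidin-4-yl ring would compare with these groups.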